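The source may report more compounds than this note shows. Statements on the series, on what has been measured and on what is new or still open speak of the compounds shown alone.

Compound 1 `CC(C)C(NC(=O)NO)C(=O)NC1CCCCC1` serves as the reference in a functional assay on WI-38 cells (Homo sapiens) for inhibition (on this read-out lower numbers stand for stronger inhibition and higher numbers for weaker inhibition), where compound 1 gives 58800 nM. Compound 2 `CCC(C)C(NC(=O)NO)C(=O)NC1CCCCC1` carries methyl in place of hydrogen on a saturated chain carbon, three bonds along the chain from an amide-type nitrogen and a carbonyl carbon. In this assay compound 2 reaches only the limit of > 100000 nM. The step is an at least 1.7-fold higher number from compound 1 to compound 2 (0.23 log units; that floor lies within the scatter), so the floor cannot be separated from scatter. Compound 3 `CC(C)C(NC(=O)n1nnc2ccccc21)C(=O)NC1CCCC1` belongs to a second core; the difference between the two cores is not broken down here. In this assay compound 3 also sits at a limit, >= 100000 nM. Compound 4 `CCC(C)C(NC(=O)n1nnc2ccccc21)C(=O)NC1CCCC1` is the same change on this core: methyl in place of hydrogen on a saturated chain carbon, three bonds along the chain from an amide-type nitrogen and a carbonyl carbon. Compound 4 is not yet measured. The expected step is a step that the limit leaves unreadable from compound 3 to compound 4, resting on an at least 1.7-fold higher number from compound 1 to compound 2 (0.23 log units; that floor lies within the scatter) and on (the limit of >= 100000 nM in this assay, at which 1 of the 3 values shown sits), at which compound 3 already stands. Compound 4 is therefore expected at 150000 nM. Its expected range runs from 80000 nM to 400000 nM.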

Compound 4, half-maximal inhibitory concentration: > 100000 nM
Compound 4 was reported as a limit (the forecaster's own chance of this, stated with the estimate: 85%); the middle value does not contradict the limit.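

In this assay compound 3 gives >= 100000 nM as a limit. For the compounds shown here, compound 4 gives > 100000 nM as a limit too, so no step from compound 3 to compound 4 can be read. The compounds shown leave open whether methyl in place of hydrogen changes inhibition on this core.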